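The compounds below may be only part of what the source reports. "The series", "measured", "known", "first", "only" and "open" are said of these compounds alone.

Compound 1 `O=c1cc(CSC(=S)N2CCCCC2)oc2ccccc12` was tested in a functional assay on MCF7 cells (Homo sapiens) for antiproliferative activity, read by MTT assay, with a stated time of 72 h (a lower number here means a stronger inhibitor, a higher number a weaker inhibitor), and gave > 25000 nM, which is a limit of the assay rather than a number. Compound 2 `COc1ccc2oc(CSC(=S)N(C(C)C)C(C)C)cc(=O)c2c1` gave > 25000 nM in this assay, again a limit and not a number. Compound 2 therefore stands at the limit of > 25000 nM in this assay, at which 2 of the 2 values shown sit. Compound 3 `COc1ccc2oc(CSC(=S)N3CCCCC3)cc(=O)c2c1` keeps the shared core and differs from compound 2 by piperidin-1-yl in place of diisopropylamino on a thiocarbonyl carbon. Among the measured compounds shown here, no measured step between two compounds covers this change. The expected step that the limit leaves unreadable from compound 2 to compound 3 is none beyond the usual scatter. Compound 3 is therefore estimated at 40000 nM, within a range from 25000 nM to 100000 nM, most likely again reported only as a limit.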

Compound 3, half-maximal inhibitory concentration: 10000 nM
The estimate for compound 3 lay 4.0-fold (0.60 log units) above the measured number; measured number outside the range, below it.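

Piperidin-1-yl in place of diisopropylamino on a thiocarbonyl carbon makes a real difference in this assay: an at least 2.5-fold lower number from compound 2 to compound 3 (0.39 log units; beyond the scatter). Methoxy in place of hydrogen on an aromatic carbon, with piperidin-1-yl kept, also matters: an at least 2.5-fold lower number from compound 1 to compound 3 (0.39 log units; beyond the scatter). Of the three compounds, only compound 3 carries both groups, and only it gives a number rather than a limit: the limit of > 25000 nM in this assay, at which 2 of the 3 values shown sit.

Going by these compounds, both steps start from a limit, so their full size stays unknown. On these data alone, whether a morpholine ring on the thiocarbonyl carbon, or chlorine in place of methoxy, would lower the number further remains open.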